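Adding a Methoxy Group to Compound 2

The source may hold more compounds than are shown below. What is called first, only, known or untested is meant among the compounds shown, and "the series" means these compounds.

Compound 1, `COc1ccccc1C(=O)Nc1ccc(Cl)cc1F`: in an ADME assay on RAW264.7 cells (Mus musculus) for cytotoxicity, read by MTT assay, with a stated time of 24 h (a higher number here means that more compound is tolerated, a lower number that less compound is tolerated), compound 1 gives > 40000 nM, which is a limit of the assay.
Compound 2, `O=C(Nc1ccc(Cl)cc1F)c1ccccc1`: in this assay compound 2 gives > 40000 nM, which is a limit of the assay.
Compound 3, `COc1ccc2c(=O)n(-c3ccc(Cl)cc3F)c(=O)oc2c1`: in this assay compound 3 gives > 40000 nM, which is a limit of the assay.

Compound 2 therefore stands at the limit of the assay, and it shares that position with every other measured compound, since (the limit of > 40000 nM in this assay, at which 3 of the 3 values shown sit). Among the compounds with values here, the one measured step that touches the same kind of change, a step that the two limits leave unreadable from compound 1 to compound 2, cannot be read in size or direction. Compound 4, `COc1ccc(C(=O)Nc2ccc(Cl)cc2F)cc1`, differs from compound 2 by methoxy in place of hydrogen on an aromatic carbon. No readable step exists on which to build a prediction, so the expectation for compound 4 rests only on the fact that compound 1, compound 2 and compound 3 all sit at the limit. On that basis the step that the limit leaves unreadable from compound 2 to compound 4 is estimated to be none beyond the scatter, with compound 4 most likely reported as a limit again. Compound 4 is thus estimated at 60000 nM, within a range of 20000 nM to 200000 nM.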

Compound 4, half-maximal cytotoxic concentration: > 40000 nM
Compound 4: no number, only a limit (the forecaster's own chance of this, stated with the estimate: 85%); the middle value lies beyond the limit too.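

In this assay compound 4 gives > 40000 nM, which is a limit of the assay. The change from compound 2 to compound 4 therefore cannot be read in size or direction: the limit of > 40000 nM in this assay, at which 4 of the 4 values shown sit.

The compounds shown leave open at what concentration any of them harms these cells, and whether adding methoxy changes that concentration.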